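This account rests on a few compounds, and the source may have more. Where it says the series, first, only, none or still open, it means among the compounds named here.

Working notes on the series. For the measured compounds named here, the three measured members share one core and differ only in the substituent on the fused benzothiazole: compound 1 `O=c1cc(-c2ccccc2)oc2cc(OCCCCNc3nc4ccc(Cl)cc4s3)cc(O)c12` carries chloro, compound 2 `O=c1cc(-c2ccccc2)oc2cc(OCCCCNc3nc4ccc(Br)cc4s3)cc(O)c12` bromo, and compound 3 `O=c1cc(-c2ccccc2)oc2cc(OCCCCNc3nc4ccc(I)cc4s3)cc(O)c12` iodo. In a functional assay on HeLa cells (Homo sapiens) for cytotoxicity, read by sulforhodamine B assay, with a stated time of 48 h (a higher number here means a weaker inhibitor, a lower number a stronger inhibitor), compound 1 gives 5.95 ug/mL; in this assay compound 2 gives 6.56 ug/mL; in this assay compound 3 gives 8.12 ug/mL. The halogen walk produces no movement worth the name: a 1.1-fold higher number from compound 1 to compound 2 (0.04 log units; within the scatter), a 1.4-fold higher number from compound 1 to compound 3 (0.14 log units; within the scatter) and a 1.2-fold higher number from compound 2 to compound 3 (0.09 log units; within the scatter). Compound 3 therefore sits at the highest of the three numbers, yet within the scatter of both of its neighbours, so the three are treated as one level.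

Compound 4 `O=C(O)c1ccc2nc(NCCCCOc3cc(O)c4c(=O)cc(-c5ccccc5)oc4c3)sc2c1` is the next member to be measured. Relative to compound 3 the change is carboxy in place of iodo on an aromatic carbon. Going by the values given here, none of the measured steps covers this kind of replacement; they only show that swapping one halogen for another at this site leaves this assay unchanged. That gives no basis for a direction, and a carboxy group is a different class of substituent, so the expectation is a wider band centred near compound 3. The expected step is a 1.2-fold higher number from compound 3 to compound 4 (0.09 log units; within the scatter). Compound 4 is estimated at 10 ug/mL, with a range from 4 ug/mL to 30 ug/mL.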

Compound 4, half-maximal inhibitory concentration: 8.43 ug/mL
Estimate against measurement, compound 4: 1.2-fold (0.07 log units) above, within the range that was stated.
By their numbers in this assay, from the lowest: compounds 1, 2, 3 and 4 (each within the scatter of the next).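

In this assay, carboxy is the only non-halogen group shown on this aromatic carbon, and its replacement of iodo gives no separation from the halogen compounds (step: a 1.0-fold higher number from compound 3 to compound 4 (0.02 log units; within the scatter)). The same holds against the other two halogens (steps: a 1.3-fold higher number from compound 2 to compound 4 (0.11 log units; within the scatter); a 1.4-fold higher number from compound 1 to compound 4 (0.15 log units; within the scatter)), so the single level seen across chloro, bromo and iodo now extends to a group of a different class, one with 3 heavy atoms in place of 1 and with a hydrogen-bond donor and acceptor where iodo has neither. No measurement available here bears on why these substituents read alike at this position.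

As far as these compounds go, whether this level also holds for an amine, an amide or a methoxy group on the same carbon remains open, as does the effect of a longer chain between the benzothiazole amine and the ether oxygen. All four compounds are read only in this assay, so whether the 6-carboxy-1,3-benzothiazol-2-yl and 6-iodo-1,3-benzothiazol-2-yl compounds also read alike on any other cell type is unsettled.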